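A Fluoro Added Ortho to Trifluoromethyl on Compound 3

A few compounds are considered here, and "the series" means these few. Any claim that something is new, unique, unknown or untested is made for them only; others in the source may bear on it.

Measured in a functional assay on A549 cells (Homo sapiens) for inhibition, read by MTT assay and WST assay, with a stated time of 72 h, tested at 10 uM; on this read-out higher numbers stand for more inhibition of growth at the one concentration tested and lower numbers for less inhibition of growth:
compound 1, `O=C(Nc1ccc(Cl)cc1)Nc1ccc(Oc2ccc(-c3ncc[nH]3)cc2)cc1`, 8.86%
compound 2, `O=C(Nc1ccc(Oc2ccc(-c3ncc[nH]3)cc2)cc1)Nc1ccc(Cl)c([N+](=O)[O-])c1`, 12.4%
compound 3, `O=C(Nc1ccc(Oc2ccc(-c3ncc[nH]3)cc2)cc1)Nc1cccc(C(F)(F)F)c1`, 30%

Compound 3 stands highest of the three numbers in this assay. Its nearest neighbour is compound 2, which lies below it by a number 17.6 percentage points higher from compound 2 to compound 3 (beyond the scatter), and its furthest is compound 1, below it by a number 21.1 percentage points higher from compound 1 to compound 3 (beyond the scatter); both of these steps are beyond the scatter, so compound 3 is the strongest of the three. The step from compound 1 to compound 2, a number 3.5 percentage points higher from compound 1 to compound 2 (within the scatter), falls within the scatter.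

Compound 4, `O=C(Nc1ccc(Oc2ccc(-c3ncc[nH]3)cc2)cc1)Nc1ccc(F)c(C(F)(F)F)c1`, has not yet been measured. It differs from compound 3 by fluoro in place of hydrogen on an aromatic carbon. Within the data shown here, no measured pair adds a fluoro; the only step that adds a single small group to the aryl ring on the urea nitrogen is the one from compound 1 to compound 2, which stayed within the scatter. The two steps that moved the number beyond the scatter each exchanged the whole aryl group rather than adding one atom to it. On this basis the expected step in this assay is none beyond the scatter, a number 3 percentage points higher from compound 3 to compound 4 (within the scatter), with a slight lean upward. Compound 4 is therefore estimated at 33%, within 18% to 50%.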

Compound 4, percent growth inhibition at one concentration: 63.3%
For compound 4 the middle estimate is 30.3 percentage points below the measured one; measured number outside the range, above it.
By their numbers in this assay, from the lowest: compounds 1 and 2 (each within the scatter of the next); then compound 3; then compound 4.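

In this assay, a fluoro on the aromatic carbon ortho to a trifluoromethyl group and para to a large group gives a number 33.3 percentage points higher from compound 3 to compound 4 (beyond the scatter), so adding one atom to the aryl ring on the urea nitrogen can move this read-out well beyond the scatter, whereas the one earlier addition of a single group, a nitro, gave only a number 3.5 percentage points higher from compound 1 to compound 2 (within the scatter) on a different aryl ring. The 4-fluoro-3-(trifluoromethyl)phenyl group also stands clear of the two other aryl groups, with a number 50.9 percentage points higher from compound 2 to compound 4 (beyond the scatter) and a number 54.4 percentage points higher from compound 1 to compound 4 (beyond the scatter), which makes it the strongest of the four shown, with every step to the others beyond the scatter. Nothing in the information given explains why so small a change at this position has so large an effect.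

Going by these compounds, it remains open whether this rise belongs to fluoro itself or would also come with chloro, methyl, methoxy or a nitrile on the same carbon. On these data alone, it is also open whether fluoro would act alike without the trifluoromethyl group, as on a plain 4-fluorophenyl group on the urea nitrogen.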